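Swapping one ring end of a paired histamine H2 agonist

The compounds below may be only part of what the source reports. "The series", "measured", "known", "first", "only" and "open" are said of these compounds alone.

Measured so far:
- compound 1 `Cc1nc(N)sc1CCCN/C(N)=N/C(=O)CCCCC(=O)/N=C(\N)NCCCc1sc(N)nc1C`: 0.68
- compound 2 `Cc1nc(N)sc1CCCN/C(N)=N/C(=O)CCCCCCCCC(=O)/N=C(\N)NCCCc1sc(N)nc1C`: 0.53
- compound 3 `N/C(=N\C(=O)CCCCCCCCC(=O)/N=C(\N)NCCCc1cnc(N)s1)NCCCc1cnc(N)s1`: 0.75

In an in vitro functional assay on Sf9 cells for agonist activity at histamine H2 receptor (Homo sapiens) (a lower number here means a smaller maximal response, a higher number a larger maximal response), compound 2 gives the lowest of the three numbers. Compound 1 lies higher by a gap beyond the usual scatter, and compound 3 lies higher still, also beyond the scatter. Compound 4 `Cc1nc(N)sc1CCCN/C(N)=N/C(=O)CCCCCCCCC(=O)/N=C(\N)NCCCc1c[nH]cn1` has not yet been measured. It differs from compound 2 in one place: 1H-imidazol-4-yl in place of 2-amino-4-methyl-1,3-thiazol-5-yl on a saturated chain carbon, three bonds along the chain from an amine nitrogen. Within the data shown here, no measured pair shows this change, so no step for it is known. The expected step from compound 2 to compound 4 is estimated as small, upward at most, and possibly none beyond the scatter: a number 0.070 higher from compound 2 to compound 4 (within the scatter). Compound 4 is therefore expected to give about 0.6, with a range from 0.4 to 0.8.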

Compound 4, intrinsic activity: the largest response reached, as a fraction of the reference agonist's: 0.76
Estimate against measurement, compound 4: 0.16 below, within the range that was stated.
By their numbers in this assay, from the lowest: compound 2; then compounds 1, 3 and 4 (each within the scatter of the next).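

In this assay, putting 1H-imidazol-4-yl in place of one 2-amino-4-methyl-1,3-thiazol-5-yl gives a number 0.23 higher from compound 2 to compound 4 (beyond the scatter). This position therefore matters: changing the group at one end alone moves the maximal response, with the chain and the other end left as they were. Nothing at hand gives a reason for this step.

As far as these compounds go, whether a phenyl group on the same chain carbon would give a similar response remains open. So does whether this swap gives a step of similar size with a longer chain.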